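This account rests on a few compounds, and the source may have more. Where it says the series, first, only, none or still open, it means among the compounds named here.

Of the compounds shown here, two built on one shared core have been measured in a functional assay on MCF7 cells (Homo sapiens) for inhibition, read by sulforhodamine B assay, with a stated time of 72 h; a lower number here means a stronger inhibitor, a higher number a weaker inhibitor. In this assay compound 1 (`C[C@H](OC(=O)/C=C\c1ccc(O)cc1)[C@@H]1CC[C@H]([C@H](O)[C@H]2CC=CC(=O)O2)O1`) gives 9300 nM. Compound 2 (`C[C@H](OC(=O)/C=C/c1ccc(O)cc1)[C@@H]1CC[C@H]([C@H](O)[C@H]2CC=CC(=O)O2)O1`) gives > 10000 nM, which is a limit of the assay and not a number, so compound 2 has no exact position on the scale. Among the compounds with values here, the one measured step is an at least 1.0-fold higher number from compound 1 to compound 2 (0.03 log units; that floor lies within the scatter), and it belongs to a pair defined by the fact that compounds 1 and 2 differ only in the configuration as drawn.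

Compound 3 (`C[C@H](OC(=O)/C=C/c1ccc(O)c(O)c1)[C@@H]1CC[C@H]([C@H](O)[C@H]2CC=CC(=O)O2)O1`) has yet to be measured. It departs from compound 2 by hydroxy in place of hydrogen on an aromatic carbon, which turns 4-hydroxyphenyl into 3,4-dihydroxyphenyl, with hydroxy in place of hydrogen on an aromatic carbon. Within the data shown here, no measured step involves a change of this kind, so the step between compound 1 and compound 2 offers only a weak guide, and its size comes from a limit. With nothing pointing to a larger shift, no step beyond the scatter is expected in this assay. The expected step is an at least 1.1-fold lower number from compound 2 to compound 3 (0.04 log units; that floor lies within the scatter). For compound 3 the estimated value is 9000 nM, with an expected range from 3000 nM to 20000 nM.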

Compound 3, half-maximal inhibitory concentration: > 10000 nM
Compound 3 ended at the assay's limit; the forecaster's own chance of this, stated with the estimate: 45%; at least 1.1-fold (0.04 log units) between middle value and limit.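

The step from compound 2 to compound 3 cannot be read, because both compounds end at a limit of the assay and not at a number: the limit of > 10000 nM in this assay, at which 2 of the 3 values shown sit.

The compounds shown leave open whether hydroxy in place of hydrogen on the aromatic carbon, which turns 4-hydroxyphenyl into 3,4-dihydroxyphenyl, changes the number in this assay at all.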